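This account rests on a few compounds, and the source may have more. Where it says the series, first, only, none or still open, it means among the compounds named here.

In a functional assay on SW-620 cells (Homo sapiens) for inhibition (on this read-out higher numbers stand for weaker inhibition of growth and lower numbers for stronger inhibition of growth), compound 1 (`COc1cc(/C=C/C(=O)c2cccc(-n3cc(-c4ccc(Cl)cc4)[nH]c3=O)c2)cc(OC)c1OC`) gives 1750 nM and compound 2 (`COc1cc(/C=C/C(=O)c2cccc(-n3cc(-c4ccccc4)[nH]c3=O)c2)ccc1O`) gives 2290 nM. For the measured compounds named here, these two values lie within the usual scatter of each other, so compound 1 cannot be separated from the only other measured compound. Compound 3 (`COc1cc(/C=C/C(=O)c2cccc(-n3cc(-c4cc(OC)c(OC)c(OC)c4)[nH]c3=O)c2)cc(OC)c1OC`) has 3,4,5-trimethoxyphenyl in place of 4-chlorophenyl on an aromatic carbon. Going by the values given here, no measured step shows what this change does, so no shift beyond the scatter is expected in this assay. The estimated step is a 1.2-fold lower number from compound 1 to compound 3 (0.07 log units; within the scatter). Among the compounds with values here, only two measured values support this, which leaves the range wide. For compound 3 the estimated value is 1500 nM, with a range of 500 nM to 4500 nM.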

Compound 3, concentration for 50% growth inhibition: 1030 nM
Estimate against measurement, compound 3: 1.5-fold (0.16 log units) above; the measured number falls inside the stated range.
By their numbers in this assay, from the lowest: compounds 3, 1 and 2 (each within the scatter of the next, the first and the last beyond it).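

In this assay, replacing 4-chlorophenyl with 3,4,5-trimethoxyphenyl gives a 1.7-fold lower number from compound 1 to compound 3 (0.23 log units; within the scatter) and so does not separate the two compounds. This aromatic carbon therefore carries a group of 12 heavy atoms with 3 hydrogen-bond acceptors, in place of one of 7 heavy atoms with none, without a shift beyond the scatter. No measurement here explains this result. From the compounds shown here alone, whether an amine or a carboxylic acid at this position would move the number beyond the scatter remains open.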